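Phenoxy to piperidin-4-yl on the benzyl arm of compound 1

The compounds below may be only part of what the source reports. "The series", "measured", "known", "first", "only" and "open" are said of these compounds alone.

In an assay on isolated protein for inhibition of Myeloperoxidase (Homo sapiens), with a stated time of 10 min (a lower number here means a stronger inhibitor, a higher number a weaker inhibitor), compound 1 `Nc1cc(Cc2ccn(Cc3cccc(Oc4ccccc4)c3)n2)c2nn[nH]c2n1` gives 44 nM. Against the other two members of the series, this is the second highest number of the three. Compound 2 `Nc1cc(Cc2ccn(-c3cccc(-c4ccccc4)c3)n2)c2nn[nH]c2n1` gives 85 nM in this assay, and the two numbers sit within the scatter of each other, so no order between compound 1 and compound 2 is read. Compound 3 `Nc1cc(C2CCNCCc3cccc(c3)Oc3cccc(c3)Cn3cc2cn3)c2nn[nH]c2n1`, the ring-closed member, gives 14 nM, a lower number than that of compound 1 and a gap that lies beyond the scatter.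

Compound 4 `Nc1cc(Cc2ccn(Cc3cccc(C4CCNCC4)c3)n2)c2nn[nH]c2n1` is not yet measured. It differs from compound 1 in one place: piperidin-4-yl in place of phenoxy on an aromatic carbon, a basic saturated ring with one hydrogen-bond donor taking the place of the second aromatic ring. For the measured compounds named here, no measured pair shows this exact exchange, so the expectation rests only on the spread of the three numbers in this assay. A small step toward a lower number is expected for compound 4, of a size that may stay within the scatter. The estimate for compound 4 in this assay is 30 nM, with a range from 12 nM to 80 nM. The step this implies is estimated as a 1.5-fold lower number from compound 1 to compound 4 (0.17 log units; within the scatter).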

Compound 4, half-maximal inhibitory concentration: 100 nM
For compound 4 the middle estimate is 3.3-fold (0.52 log units) below the measured one; the whole stated range lies below it.
By their numbers in this assay, from the lowest: compound 3; then compounds 1, 2 and 4 (each within the scatter of the next, the first and the last beyond it).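

In this assay, for the compounds shown here, the exchange of phenoxy for piperidin-4-yl on the benzyl arm gives a 2.3-fold higher number from compound 1 to compound 4 (0.36 log units; beyond the scatter), the first change that can be read at a single place. This aromatic carbon, meta to a large group, therefore accepts a non-aromatic ring with a hydrogen-bond donor at the cost of only a modest step, so a second aromatic ring is not required there for a value of 100 nM in compound 4, although piperidin-4-yl does not match phenoxy at this place. No measurement at hand accounts for the size or direction of this step.

This single exchange does not separate the loss of the aromatic ring from the arrival of the ring nitrogen and its hydrogen, and cyclohexyl or tetrahydropyran-4-yl on the same carbon would pull these two apart. As far as these compounds go, it also remains open whether a substituted ring nitrogen, as in 1-methylpiperidin-4-yl, or a phenyl ring attached directly to the same carbon would move the number in either direction.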